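A few compounds are considered here, and "the series" means these few. Any claim that something is new, unique, unknown or untested is made for them only; others in the source may bear on it.

Three compounds with a shared core have numbers in a physicochemical assay for solubility, read by HPLC, using the shake flask method, with a stated time of 2 h, at pH 2; on this read-out higher numbers stand for higher solubility and lower numbers for lower solubility. In this assay, compound 1 `Nc1ncc(-c2ccc(C(=O)N3CC(O)C3)cc2)nc1-c1ccc(C(F)(F)F)cc1` gives 110000 nM and compound 2 `Nc1ncc(-c2ccc(C(=O)N3CCC(O)C3)cc2)nc1-c1ccc(C(F)(F)F)cc1` gives 129000 nM. Among the measured compounds shown here, the measured step, a 1.2-fold higher number from compound 1 to compound 2 (0.07 log units; within the scatter), leaves the two level, so compound 2 stands with compound 1 as one of only two exact numbers. Compound 3 `COC(=O)c1ccc(-c2cnc(N)c(-c3ccc(C(F)(F)F)cc3)n2)cc1` gives < 5000 nM, which is a limit of the assay and not a number. Placing methoxy on the carbonyl in place of the hydroxylated rings gave two large steps, an at least 22-fold lower number from compound 1 to compound 3 (1.34 log units; beyond the scatter) and an at least 25-fold lower number from compound 2 to compound 3 (1.41 log units; beyond the scatter).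

Compound 4 `Nc1ncc(-c2ccc(C(=O)N3CCC(N)C3)cc2)nc1-c1ccc(C(F)(F)F)cc1` has not yet been measured. It differs from compound 2 by amino in place of hydroxy on a saturated ring carbon, two ring bonds from the ring nitrogen. For the measured compounds named here, no measured step makes this exchange. The two large steps remove the whole ring, whereas compound 4 keeps the ring of compound 2, so they bear on it only loosely. The closer guide is the ring change in compound 2, a 1.2-fold higher number from compound 1 to compound 2 (0.07 log units; within the scatter), and on that basis no step beyond the scatter is expected in either direction. The expected change is a 1.2-fold higher number from compound 2 to compound 4 (0.07 log units; within the scatter). The estimate for compound 4 is 150000 nM, with an expected range of 80000 nM to 300000 nM.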

Compound 4, solubility: 165000 nM
Compound 4: middle estimate off by 1.1-fold (0.04 log units), on the low side; measured number inside the range.
By their numbers in this assay, from the lowest: compounds 1, 2 and 4 (each within the scatter of the next). At a limit, below all of these: compound 3.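

Exchanging hydroxy for amino on the saturated ring carbon, two ring bonds from the ring nitrogen, now has a measured step in this assay, a 1.3-fold higher number from compound 2 to compound 4 (0.11 log units; within the scatter), so the two groups stand level at this place. The 3-aminopyrrolidin-1-yl amide also stands level with the smaller hydroxylated ring, with a 1.5-fold higher number from compound 1 to compound 4 (0.18 log units; within the scatter), while the large step seen on going to the methoxy ester of the hydroxylated rings now appears with an amino-bearing ring as well, in an at least 33-fold higher number from compound 3 to compound 4 (1.51 log units; beyond the scatter). That last step has only a lower bound, since the value of compound 3 is a limit of the assay and not a number: the limit of < 5000 nM in this assay, at which 1 of the 4 values shown sits.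

As far as these compounds go, compound 1, compound 2 and compound 4 all carry a hydroxy or amino group on the ring, so it remains open whether a plain pyrrolidin-1-yl amide, with neither group, would stand with them or sit nearer compound 3. From the compounds shown here alone, it also remains open how a carboxylic acid or an aminomethyl chain on that same ring carbon would read.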